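Chlorobenzyl Regioisomers in a Hamster Cell Cytotoxicity Assay

The source may hold more compounds than are shown below. What is called first, only, known or untested is meant among the compounds shown, and "the series" means these compounds.

Compound 1 `CC(Sc1nnc(-c2ccncc2)s1)C(=O)NCc1ccccc1Cl`: > 50000 nM
Compound 2 `CC(Sc1nnc(-c2ccncc2)s1)C(=O)NCc1ccc(Cl)cc1`: "not determined" (no result reported)
Compound 3 `O=C(CSc1nnc(-c2ccncc2)s1)NCc1ccccc1Cl`: "not determined" (no result reported)

In an ADME assay on BHK-21 cells (Mesocricetus auratus) for cytotoxicity, with a stated time of 3 days (a lower number here means that less compound is tolerated, a higher number that more compound is tolerated), compound 1 reaches only a limit of the assay, > 50000 nM. Compound 2 has no result in this assay, "not determined" (no result reported). Compound 3 likewise has no number in this assay, "not determined" (no result reported). Beside it stand one further entry without a number and, from compound 1, one entry that is a limit, namely (the limit of > 50000 nM in this assay, at which 1 of the 3 values shown sits). Compound 4 `O=C(CSc1nnc(-c2ccncc2)s1)NCc1ccc(Cl)cc1` differs from compound 3 by 4-chlorophenyl in place of 2-chlorophenyl on a saturated chain carbon bound to an amide-type nitrogen. Among the compounds with values here, no measured step exists for this change, and no shift beyond the scatter is expected in this assay in either direction. Compound 4 is estimated at 60000 nM, between 25000 nM and 150000 nM, most likely again only a limit.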

Compound 4, half-maximal cytotoxic concentration: > 50000 nM
Compound 4 gave a limit, no number; the forecaster's own chance of this, stated with the estimate: 75%; the middle value does not contradict the limit.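

Compound 4 reaches only a limit, > 50000 nM. Compound 3 has no number, and no step can be read between compound 3 and compound 4. The compounds shown leave open whether 2-chlorobenzyl to 4-chlorobenzyl shifts the read-out at all.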